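Chain against ring on the benzimidazole-free view of compound 3

The source may report more compounds than this note shows. Statements on the series, on what has been measured and on what is new or still open speak of the compounds shown alone.

The measured compounds:
compound 1, `CN1CCN(c2nc3ccccc3n2CCO)CC1`, 410 nM
compound 2, `CCCCCCn1c(N2CCN(C)CC2)nc2ccccc21`, 26 nM
compound 3, `CN1CCN(c2nc3ccccc3n2-c2ccccc2)CC1`, 760 nM

In a functional assay on ileum for inhibition of histamine H1 receptor (Cavia porcellus) (a lower number here means a stronger inhibitor, a higher number a weaker inhibitor), compound 3 gives the highest of the three numbers. Its nearest neighbour is compound 1, and the step of a 1.9-fold higher number from compound 1 to compound 3 (0.27 log units; within the scatter) lies within the scatter, so the two are not ordered. Its furthest neighbour is compound 2, and the step of a 29-fold higher number from compound 2 to compound 3 (1.47 log units; beyond the scatter) is large.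

Compound 4, `C#CCOCCn1c(N2CCN(C)CC2)nc2ccccc21`, arises from compound 3 by the change (2-(propargyloxy)ethyl in place of phenyl on an aromatic nitrogen). Among the measured compounds shown here, the step that bears most directly on it is the one from compound 2 to compound 3, where a phenyl in place of hexyl on the same aromatic nitrogen brought a large rise; compound 4 reverses that direction by putting a six-heavy-atom chain back in place of the ring. The step of a 16-fold lower number from compound 1 to compound 2 (1.20 log units; beyond the scatter) shows that a plain alkyl chain gave the strongest number, while the oxygen-bearing 2-hydroxyethyl of compound 1 stayed close to compound 3. The entering chain carries one oxygen, so compound 4 is expected to fall between compound 1 and compound 2, a lowering beyond the scatter of a 6.9-fold lower number from compound 3 to compound 4 (0.84 log units; beyond the scatter). Compound 4 is therefore estimated at 110 nM, with a range from 35 nM to 350 nM.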

Compound 4, half-maximal inhibitory concentration: 12 nM
For compound 4 the middle estimate is 9.2-fold (0.96 log units) above the measured one; the whole stated range lies above it.
By their numbers in this assay, from the lowest: compound 4; then compound 2; then compounds 1 and 3 (each within the scatter of the next).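

In this assay, the swap of phenyl for 2-(propargyloxy)ethyl gives a 63-fold lower number from compound 3 to compound 4 (1.80 log units; beyond the scatter) and shows that a ring is not needed on this aromatic nitrogen, since a chain with no ring and the same count of heavy atoms takes its place with a large fall in the number. An oxygen in the chain does not in itself keep the number high, for the change at the far end of the chain from 2-hydroxyethyl, propargyl in place of hydrogen on the oxygen, gives a 34-fold lower number from compound 1 to compound 4 (1.53 log units; beyond the scatter) and so turns a chain that stood level with the phenyl into the lowest of the series. Among the compounds shown here, the comparison with the plain hexyl chain, a 2.2-fold lower number from compound 2 to compound 4 (0.34 log units; beyond the scatter) and thus a modest step beyond the scatter, shows that the new chain even goes past the alkyl chain, which the earlier compounds gave no sign of.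

Nothing available explains why these steps run as they do. On these data alone, whether the triple bond or the ether oxygen accounts for the gain over hexyl stays open, as does how a longer chain or a chain ending in an amine would read on this nitrogen.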